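Amide variation on the shared core: propyl to cyclopropyl

The compounds below may be only part of what the source reports. "The series", "measured", "known", "first", "only" and "open" are said of these compounds alone.

Among the measured compounds shown here, compound 3 `CCCC(=O)NCCCc1cccc2c1C[C@@H](CCCCc1ccccc1)O2` gives 30 nM in an assay on NIH3T3 cells for binding affinity to melatonin receptor type 1B (Homo sapiens); on this read-out higher numbers stand for weaker inhibition and lower numbers for stronger inhibition; among the three numbers so far it stands second highest. For the measured compounds named here, compound 1 `CC(C)C(=O)NCCCc1cccc2c1C[C@@H](CCCCc1ccccc1)O2` gives 40 nM, and the step of a 1.3-fold lower number from compound 1 to compound 3 (0.12 log units; within the scatter) is the only measured change at a carbonyl carbon. Going by the values given here, compound 2 `O=C(NC[C@@H]1C[C@H]1c1cccc2c1C[C@@H](CCCCc1ccccc1)O2)C1CC1` gives 5 nM, but it differs from compound 3 in more than one place, so no single step connects the two. Compound 4 `O=C(NCCCc1cccc2c1C[C@@H](CCCCc1ccccc1)O2)C1CC1` differs from compound 3 by cyclopropyl in place of propyl on a carbonyl carbon. Among the compounds with values here, since the one measured step at the carbonyl carbon stayed within the scatter, little movement is expected in this assay; the lower number of compound 2 allows a modest lowering. Compound 4 is therefore estimated at 20 nM (range 8 nM to 50 nM), an expected step of a 1.5-fold lower number from compound 3 to compound 4 (0.18 log units; within the scatter).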

Compound 4, inhibition constant: 30 nM
For compound 4 the middle estimate is 1.5-fold (0.18 log units) below the measured one, and the stated range covers the measured number.
By their numbers in this assay, from the lowest: compound 2; then compounds 3, 4 and 1 (each within the scatter of the next).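

Propyl, isopropyl and cyclopropyl on this carbonyl carbon cannot be told apart in this assay with no change at the digits printed from compound 3 to compound 4 (within the scatter) and a 1.3-fold lower number from compound 1 to compound 4 (0.12 log units; within the scatter) as the two new steps. Compound 2 carries the same cyclopropyl on the carbonyl carbon, so that group alone does not separate compound 2 at 5 nM from compound 4 at 30 nM in this series. No measurement at hand explains why these groups read alike. Open, as far as these compounds go, is whether a longer chain, such as hexyl, or an amine at this carbonyl carbon would stay equally flat.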